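Moving the pyridine nitrogen in the urea series

The source may hold more compounds than are shown below. What is called first, only, known or untested is meant among the compounds shown, and "the series" means these compounds.

In a physicochemical assay for lipophilicity, read by HPLC, measured as octanol-water partition, at pH 7.2 (a lower number here means a more polar compound, a higher number a more lipophilic compound), compound 1 (`O=C(Nc1ccc(F)c(C(F)(F)F)c1)Nc1cnccn1`) gives 3 and compound 2 (`O=C(Nc1cccnc1)Nc1ccc(F)c(C(F)(F)F)c1`) gives 3, so compound 2 stands level with compound 1. The next structure is compound 3 (`O=C(Nc1ccncc1)Nc1ccc(F)c(C(F)(F)F)c1`), and the change is pyridin-4-yl in place of pyridin-3-yl on an amide-type nitrogen. In words, pyridin-4-yl sits in place of pyridin-3-yl on an amide-type nitrogen, with the rest of the structure shared.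

For the measured compounds named here, only one measured step bears on this change: no change at the digits printed from compound 1 to compound 2 (within the scatter). That step put pyridin-3-yl in place of pyrazin-2-yl at the same place. It is a single comparison and involves a different ring exchange, so it is only a loose guide. Going by the values given here, no measurement yet separates pyridin-4-yl from pyridin-3-yl, and the direction of any shift remains poorly defined.

On this limited evidence, no step beyond the scatter is expected, and the estimated step is a number 0.10 log units lower from compound 2 to compound 3 (within the scatter). For compound 3 the expected value is 2.9, with an estimated range of 2.5 to 3.3.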

Compound 3, distribution coefficient: 3.2
Compound 3: middle estimate off by 0.30 log units, on the low side; the measured number falls inside the stated range.
By their numbers in this assay, from the lowest: compounds 1, 2 and 3 (each within the scatter of the next).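

For the compounds shown here, exchanging pyridin-3-yl for pyridin-4-yl on the amide-type nitrogen gives a number 0.20 log units higher from compound 2 to compound 3 (within the scatter) in this assay, and this is the first comparison at this place between two rings built from the same atoms joined differently. Against pyrazin-2-yl at the same place, pyridin-4-yl gives a number 0.20 log units higher from compound 1 to compound 3 (within the scatter) in this assay, so all three pairs among the compounds shown now lie within the scatter, and the reading at this place does not separate these three six-membered aromatic rings. The data offer no measured basis for explaining the small difference between compound 2 and compound 3, and it is best treated as no established shift.

On these data alone, it remains open whether this assay would stay this flat with a different kind of group on the amide-type nitrogen, such as a saturated amine, a carboxylic acid or a longer alkyl chain. Also open, as far as these compounds go, is whether the pyridin-4-yl and pyridin-3-yl exchange would read the same way if the fluoro or trifluoromethyl group in the shared core were replaced.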